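Carbamate series: methoxycarbonyl in place of acetyl on the core

This account rests on a few compounds, and the source may have more. Where it says the series, first, only, none or still open, it means among the compounds named here.

Measured in an assay on microsomes from brain (strain Sprague-Dawley) for inhibition of Fatty-acid amide hydrolase 1 (Rattus norvegicus), read by fluorescence and HPLC, with stated times of 10 min and 60 min; a higher number here means a weaker inhibitor, a lower number a stronger inhibitor:
compound 1, `Cc1c(-c2ccccc2)cc(-c2ccccc2)n1CCCCCCNC(=O)Oc1ccccc1`: 460 nM
compound 2, `O=C(NCCCCCCn1ccc2ccccc21)Oc1cccnc1`: 5.2 nM
compound 3, `CC(=O)c1c(-c2ccccc2)c(-c2ccccc2)n(CCCCCCNC(=O)Oc2ccccc2)c1C`: > 10000 nM

Compound 1 and compound 2 give numbers; compound 3 does not. For compound 3 the assay reports only a limit, > 10000 nM, and no value. That is the limit (the limit of > 10000 nM in this assay, at which 1 of the 3 values shown sits), so compound 3 stands at the weak end of what is shown, with no telling how far beyond it lies. Compound 1, whose core carries no acetyl, gives 460 nM in this assay, and compound 2, with a different core, gives 5.2 nM.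

Compound 4, `COC(=O)c1c(-c2ccccc2)c(-c2ccccc2)n(CCCCCCNC(=O)Oc2ccccc2)c1C`, differs from compound 3 by methoxy in place of methyl on a carbonyl carbon. Among the compounds with values here, no step between two measured compounds shares this change, so there is nothing measured to set its size. The acetyl of compound 3 already sits at the limit, and a methoxycarbonyl keeps the carbonyl on the core, so no step beyond the scatter is expected in either direction; the most likely outcome is that compound 4 also returns only a limit. Compound 4 is therefore estimated at 12000 nM, with a range of 2500 nM to 60000 nM. The change from compound 3 to compound 4 is expected to come out as a step that the limit leaves unreadable from compound 3 to compound 4.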

Compound 4, half-maximal inhibitory concentration: > 10000 nM
Compound 4: no number, only a limit; the forecaster's own chance of this, stated with the estimate: 60%; the middle value does not contradict the limit.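

In this assay compound 3 and compound 4 each return only a limit and no number, so no step from acetyl to methoxycarbonyl can be read between them: the limit of > 10000 nM in this assay, at which 2 of the 4 values shown sit.

The compounds shown leave open how far compound 3 and compound 4 each lie past that limit, and whether the two differ at all in this assay.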